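The compounds below may be only part of what the source reports. "The series", "measured", "known", "first", "only" and "open" are said of these compounds alone.

In a functional assay on A549 cells (Homo sapiens) for antiproliferative activity, read by MTT assay, with a stated time of 48 h (on this read-out higher numbers stand for weaker inhibition and lower numbers for stronger inhibition), compound 1 (`Fc1ccc(-c2nn(-c3ccccc3)cc2-c2nc3cc(F)ccc3[nH]2)cc1`) gives 1130 nM and compound 2 (`Fc1ccc(-c2nn(-c3ccccc3)cc2-c2nc3cc(Cl)ccc3[nH]2)cc1`) gives 1320 nM on the same read-out, so the two stand together at the only level seen so far, with nothing separating them. Compound 3 (`COc1ccc(-c2nn(-c3ccccc3)cc2-c2nc3cc(F)ccc3[nH]2)cc1`) is compound 1 with 4-fluorophenyl changed to 4-methoxyphenyl (methoxy in place of fluoro on an aromatic carbon), which is methoxy in place of fluoro on an aromatic carbon, para to a large group. Among the measured compounds shown here, only one measured step is available as a guide. It is a 1.2-fold higher number from compound 1 to compound 2 (0.07 log units; within the scatter) for chloro in place of fluoro on an aromatic carbon, and it stays within the scatter. For the measured compounds named here, that swap lies at another place in the structure and involves a different kind of group, so it bears on the present change only loosely, and no measurement yet tests this site. No step beyond the scatter is therefore expected in this assay, though the uncertainty is wide. The estimated step is a 1.2-fold higher number from compound 1 to compound 3 (0.09 log units; within the scatter) on this reading. For compound 3 the expected value is 1400 nM within an estimated range from 500 nM to 4000 nM in this series.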

Compound 3, half-maximal inhibitory concentration: 1980 nM
Compound 3: the middle estimate sits 1.4-fold (0.15 log units) below what was measured, within the range that was stated.
By their numbers in this assay, from the lowest: compounds 1, 2 and 3 (each within the scatter of the next).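

In this assay, the 4-fluorophenyl group now has its first measured change: 4-methoxyphenyl in its place gives a 1.8-fold higher number from compound 1 to compound 3 (0.24 log units; within the scatter). On this evidence, methoxy in place of fluoro on an aromatic carbon, para to a large group, brings one more heavy atom and a hydrogen-bond acceptor without a step that can be separated from the scatter, so this single swap does not show the site to be sensitive, just as the chloro-for-fluoro change elsewhere on the core gives a 1.2-fold higher number from compound 1 to compound 2 (0.07 log units; within the scatter). No measurement is available that bears on why the read-out behaves this way at this position.

Among the compounds shown here, whether an amine, a carboxylic acid or a longer alkoxy chain on this aromatic carbon would produce a step beyond the scatter remains open, since fluoro and methoxy are the only two groups seen here. Also open, from the compounds shown here alone, is whether 4-methoxyphenyl would give a similar step alongside the chloro of compound 2, as the two changes have so far been seen only separately.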